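Inverting one stereocentre of compound 2

A few compounds are considered here, and "the series" means these few. Any claim that something is new, unique, unknown or untested is made for them only; others in the source may bear on it.

Measured so far in a functional assay on cells (Macrophage, Mus musculus) for activation (on this read-out higher numbers stand for an effect only at larger amounts of compound and lower numbers for an effect already at smaller amounts), are two compounds
- Compound 1 (`CCCCCCCCCCCC(=O)O[C@H](CCCCCCCCCCC)CC(=O)N[C@H](CCOP(=O)(O)O)C(=O)NCCC[C@H](CO)NC(=O)C[C@H](O)CCCCCCCCCCC`) with value (1.85 ug/mL)
- Compound 2 (`CCCCCCCCCCCC(=O)O[C@H](CCCCCCCCCCC)CC(=O)N[C@@H](CCOP(=O)(O)O)C(=O)NCCC[C@H](COP(=O)(O)O)NC(=O)C[C@H](O)CCCCCCCCCCC`) with value (0.15 ug/mL)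

Compound 2 has the lower number of the two, and its gap to compound 1 lies beyond the scatter. Compound 3 (`CCCCCCCCCCCC(=O)O[C@H](CCCCCCCCCCC)CC(=O)N[C@H](CCOP(=O)(O)O)C(=O)NCCC[C@H](COP(=O)(O)O)NC(=O)C[C@H](O)CCCCCCCCCCC`) keeps the atoms and bonds of compound 2 (the two compounds have the same atoms and bonds and differ only in configuration as drawn: 1 of 4 stereo elements differ; a stereocentre at a saturated chain carbon is drawn S in compound 2 and R in compound 3): a stereocentre at a saturated chain carbon is drawn S in compound 2 and R in compound 3. Within the data shown here, no pair of measured compounds shows this change alone, so its size in this assay must be judged without a direct precedent. A moderate move towards a higher number is expected, although a shift within the scatter would also fit. The expected change (a 2.0-fold higher number from compound 2 to compound 3 (0.30 log units; within the scatter)) is only an estimate. For compound 3 the estimated value is (0.3 ug/mL), with an expected range from 0.08 ug/mL to 1.2 ug/mL once it is measured.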

Compound 3, half-maximal effective concentration: 0.55 ug/mL
Beside the measured number, compound 3's estimate is 1.8-fold (0.26 log units) below it, within the range that was stated.
By their numbers in this assay, from the lowest: compound 2; then compound 3; then compound 1.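

In this assay, inverting the stereocentre at the saturated chain carbon from S to R gives a 3.7-fold higher number from compound 2 to compound 3 (0.56 log units; beyond the scatter), so this position is sensitive to configuration. The step can be assigned to the inversion alone because no other part of the structure changes: the fact that compounds 2 and 3 differ only in the configuration as drawn. With this carbon drawn R in both compounds, the group of 4 heavy atoms (3 oxygen, 1 phosphorus; no ring) in place of a hydrogen atom, on an oxygen on a saturated carbon, gives a 3.4-fold lower number from compound 1 to compound 3 (0.53 log units; beyond the scatter), which shows that this group also matters when the R configuration is held.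

The compounds shown leave open whether the same inversion would shift the number in a compound with a free hydroxyl at that oxygen, as in compound 1. They also leave open how a carboxylic acid in place of that group, or a longer chain, would behave.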